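The compounds below may be only part of what the source reports. "The series", "measured", "known", "first", "only" and "open" are said of these compounds alone.

Compound 1 `CC(C)(C)C(=O)NCCCCN1CCN(c2ccc(Cl)cc2)CC1` gives in an assay on HEK293 cells for binding affinity to D(4) dopamine receptor (Homo sapiens), read by radioligand binding (on this read-out lower numbers stand for stronger inhibition and higher numbers for weaker inhibition), a value of 12.6 nM, the lowest of the three numbers at hand. Compound 3 `COc1cc(Cl)ccc1N1CCN(CCCCNC(=O)C(C)(C)C)CC1` gives 15.9 nM in this assay, and the step of a 1.3-fold higher number from compound 1 to compound 3 (0.10 log units; within the scatter) lies within the scatter. Compound 2 `CC(C)(C)C(=O)NCCCCN1CCN(c2ccc(F)cc2)CC1` gives 126 nM, and the step of a 10-fold higher number from compound 1 to compound 2 (1.00 log units; beyond the scatter) is the only one beyond the scatter.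

Compound 4 `CC(C)(C)C(=O)NCCCN1CCN(c2ccc(Cl)cc2)CC1` is not yet measured. It differs from compound 1 by ((tert-butyl)carbonyl)amino in place of (((tert-butyl)carbonyl)amino)methyl on a saturated chain carbon, three bonds along the chain from an amine nitrogen in a ring. Neither measured step touches this part of the molecule: the step from compound 1 to compound 2 and the step from compound 1 to compound 3 both concern substituents on the aromatic ring, while the chain between the ring amine nitrogen and the amide stays the same in all three measured compounds. Within the data shown here, there is therefore no measured precedent for a change of the chain, and the expectation must rest on the shared core alone. Compound 4 is expected to give a number close to that of compound 1, with a step of a 2.0-fold higher number from compound 1 to compound 4 (0.30 log units; within the scatter) that may fall within the scatter or only somewhat beyond it. The estimate for compound 4 in this assay is 25 nM, with a range from 5 nM to 125 nM.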

Compound 4, inhibition constant: 200 nM
Compound 4: the middle estimate sits 8.0-fold (0.90 log units) below what was measured; measured number outside the range, above it.
By their numbers in this assay, from the lowest: compounds 1 and 3 (each within the scatter of the next); then compounds 2 and 4 (each within the scatter of the next).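

In this assay, the position on a saturated chain carbon, three bonds along the chain from an amine nitrogen in a ring, proves sensitive: ((tert-butyl)carbonyl)amino in place of (((tert-butyl)carbonyl)amino)methyl gives a 16-fold higher number from compound 1 to compound 4 (1.20 log units; beyond the scatter). Among these compounds, the earlier steps touched only the aromatic ring, so this is the first sign that the number also responds to the chain, even though the entering group has 7 heavy atoms against 8 and the same hydrogen-bond donor and acceptor counts. No available evidence bears on the reason for this step.

The compounds shown leave open how a longer chain would read, since only these two chain lengths appear. They also leave open whether the shorter chain has a similar effect with the fluoro or methoxy substitution on the aromatic ring.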